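The source may report more compounds than this note shows. Statements on the series, on what has been measured and on what is new or still open speak of the compounds shown alone.

Measured so far:
compound 1, `OC(O)(c1c(F)c(F)c(-n2cc(-c3ccccc3)nn2)c(F)c1F)C(F)(F)F`, > 100000 nM
compound 2, `O=C(CCCCCCNC(=O)C(O)(O)C(F)(F)F)Nc1ccc(Br)cc1`, 3130 nM

In a functional assay on HCT-116 cells (Homo sapiens) for inhibition, read by colorimetric assay, with a stated time of 3 days (on this read-out lower numbers stand for stronger inhibition and higher numbers for weaker inhibition), compound 1 returns only a limit, > 100000 nM. Going by the values given here, compound 2 gives 3130 nM, the only true number among the two results, so nothing stands above or beneath it for comparison. Among the compounds with values here, no step between two measured compounds is available, and the size of a halogen exchange cannot be read from this set. Compound 3, `O=C(CCCCCCNC(=O)C(O)(O)C(F)(F)F)Nc1ccc(Cl)cc1`, differs from compound 2 by chloro in place of bromo on an aromatic carbon. Within the data shown here, with no measured step to lean on, a shift no larger than the usual scatter is expected, if anything towards weaker inhibition. Compound 3 is therefore estimated at 4000 nM, within 1500 nM to 12000 nM, the expected step being a 1.3-fold higher number from compound 2 to compound 3 (0.11 log units; within the scatter).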

Compound 3, half-maximal inhibitory concentration: 4230 nM
The estimate for compound 3 lay 1.1-fold (0.02 log units) below the measured number; the range from low to high includes it.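

In this assay, going by these compounds alone, the first measured step at this position is a 1.4-fold higher number from compound 2 to compound 3 (0.13 log units; within the scatter). On an aromatic carbon para to a large group, chloro and bromo are therefore not told apart, which compound 2 alone could not show. Nothing at hand bears on the reason for this result.

Still open, going by these compounds, is whether an amine or a methoxy group at this position would separate from the two halogens. Also open, on these data alone, is whether a longer chain would shift the number in the 4-chlorophenyl or 4-bromophenyl compounds.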